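Methoxy for chloro on a fused ring: compound 3

The source may hold more compounds than are shown below. What is called first, only, known or untested is meant among the compounds shown, and "the series" means these compounds.

Measured so far:
Compound 1 `O=C(NC1CCN(Cc2ccc(OC3CCNCC3)c(Br)c2)CC1)c1cccs1`, 130 nM
Compound 2 `O=C(NC1CCN(Cc2ccc(OC3CCNCC3)c(Br)c2)CC1)c1cc2cc(Cl)ccc2s1`, 51 nM

Both compounds were tested in an assay on HEK293 cells for displacement of a labelled ligand from Urotensin-2 receptor (Homo sapiens), read by fluorescence, with a stated time of 90 min; on this read-out lower numbers stand for stronger inhibition and higher numbers for weaker inhibition. Compound 2 holds the lower of the two numbers, and its nearest neighbour, compound 1, sits a 2.5-fold lower number from compound 1 to compound 2 (0.41 log units; beyond the scatter) away, so compound 2 is the stronger binder of the pair. Compound 3 `COc1ccc2sc(C(=O)NC3CCN(Cc4ccc(OC5CCNCC5)c(Br)c4)CC3)cc2c1` is not yet measured. It keeps the shared core of compound 2 and changes one group: methoxy in place of chloro on an aromatic carbon.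

Among the measured compounds shown here, only one measured step exists, and it concerns a different part of the molecule: the exchange of the group on the carbonyl carbon, recorded as a 2.5-fold lower number from compound 1 to compound 2 (0.41 log units; beyond the scatter). For the measured compounds named here, no measured pair shows what a methoxy in place of chloro on the fused ring does, so the size and direction of the step from compound 2 to compound 3 cannot be read from the numbers. In that situation the expectation is a step no larger than the scatter in either direction, centred on compound 2.

The estimate for compound 3 in this assay is therefore 60 nM, with a range of 25 nM to 150 nM, which corresponds to an expected step of a 1.2-fold higher number from compound 2 to compound 3 (0.07 log units; within the scatter).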

Compound 3, half-maximal inhibitory concentration: 100 nM
The estimate for compound 3 lay 1.7-fold (0.22 log units) below the measured number; measured number inside the range.
By their numbers in this assay, from the lowest: compounds 2, 3 and 1 (each within the scatter of the next, the first and the last beyond it).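

In this assay, methoxy in place of chloro on this aromatic carbon gives a 2.0-fold higher number from compound 2 to compound 3 (0.29 log units; within the scatter), so the two groups cannot be told apart at this position, even though methoxy, unlike chloro, counts as a hydrogen-bond acceptor. The comparison with the thiophen-2-yl compound adds a qualification: 5-methoxy-1-benzothiophen-2-yl in its place gives a 1.3-fold lower number from compound 1 to compound 3 (0.11 log units; within the scatter), while 5-chloro-1-benzothiophen-2-yl gave a 2.5-fold lower number from compound 1 to compound 2 (0.41 log units; beyond the scatter), so only the chloro version stands clear of the scatter, and the earlier step cannot be credited to the larger fused group whatever it carries. No supporting measurement is available to explain this result.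

The compounds shown leave open how far this position tolerates change, since chloro and methoxy are the only groups seen there, and a hydrogen atom, an amine or a carboxylic acid could reveal a larger step than this pair does. They also leave open whether chloro and methoxy would remain this close on another carbon of the same six-membered ring.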